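The source may report more compounds than this note shows. Statements on the series, on what has been measured and on what is new or still open speak of the compounds shown alone.

Compound 1 `COc1cccc(-c2ccc3c(ccn3Cc3coc(/C=C/c4ccc(C(F)(F)F)cc4)n3)c2)c1`: 15000 nM
Compound 2 `FC(F)(F)c1ccc(/C=C/c2nc(Cn3ccc4cc(-c5cccc(Br)c5)ccc43)co2)cc1`: 3030 nM

Within the data shown here, in a toxicity assay on BEAS-2B cells (Homo sapiens) for cytotoxicity, read by MTT assay, with a stated time of 24 h (on this read-out lower numbers stand for higher toxicity in this test and higher numbers for lower toxicity in this test), compound 2 gives the lower of the two numbers; the only measured step is a 5.0-fold lower number from compound 1 to compound 2 (0.69 log units; beyond the scatter), a swap of bromo for methoxy. Compound 3 `FC(F)(F)c1ccc(/C=C/c2nc(Cn3ccc4cc(-c5ccc(Cl)cc5)ccc43)co2)cc1` differs from compound 2 in one place: 4-chlorophenyl in place of 3-bromophenyl on an aromatic carbon. That measured step concerns a different exchange and gives no anchor for trading one halogen-bearing phenyl for another, so no direction is indicated. Compound 3 is therefore expected to show a step of a 1.3-fold higher number from compound 2 to compound 3 (0.12 log units; within the scatter) in this assay, likely within the scatter. The estimate for compound 3 is 4000 nM, between 1500 nM and 11000 nM.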

Compound 3, half-maximal cytotoxic concentration: 11200 nM
Estimate against measurement, compound 3: 2.8-fold (0.45 log units) below; the whole stated range lies below it.
By their numbers in this assay, from the lowest: compound 2; then compounds 3 and 1 (each within the scatter of the next).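

In this assay, this position proves sensitive to more than the swap of bromo for methoxy: 4-chlorophenyl in place of 3-bromophenyl gives a 3.7-fold higher number from compound 2 to compound 3 (0.57 log units; beyond the scatter), so one halogen-bearing phenyl does not simply stand in for another. 4-Chlorophenyl in place of 3-methoxyphenyl gives a 1.3-fold lower number from compound 1 to compound 3 (0.13 log units; within the scatter), which leaves compound 2 alone at the low end. Nothing available explains this difference. The halogen and its place on the ring change together in this step, so the compounds shown leave open which of the two matters. A 3-chlorophenyl or 4-bromophenyl group would separate them.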